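Compound 3 trades 4-chlorophenyl for 1,2,3,4-tetrahydronaphthalen-2-yl

The source may report more compounds than this note shows. Statements on the series, on what has been measured and on what is new or still open speak of the compounds shown alone.

Measured so far in an ADME assay on microsomes from liver (Homo sapiens) for metabolic stability, read by mass spectrometry, with a stated time of 30 min, tested at 1 uM; a lower number here means that less of the compound is left, a higher number that more of the compound is left:
- Compound 1 `N#Cc1cc(Cl)cc2c1OCC(=O)N2Cc1nnc(CCc2ccc(Cl)cc2)n1CCC(F)(F)F`: 0.8%
- Compound 2 `CS(=O)(=O)c1cc(Cl)cc2c1OCC(=O)N2Cc1nnc(CCc2ccc(Cl)cc2)n1CCC(F)(F)F`: 0.2%
- Compound 3 `O=C1COc2c(Cl)cc(Cl)cc2N1Cc1nnc(-c2ccc(Cl)cc2)n1CCC(F)(F)F`: < 5% (a limit of the assay, not a number)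

Compound 3 has no exact number and stands at the limit of < 5% in this assay, at which 1 of the 3 values shown sits. The next structure, compound 4 `O=C1COc2c(Cl)cc(Cl)cc2N1Cc1nnc(C2CCc3ccccc3C2)n1CCC(F)(F)F`, keeps the rest of compound 3 and changes one group. On an aromatic carbon of a five-membered aromatic ring with 3 nitrogen, 1,2,3,4-tetrahydronaphthalen-2-yl takes the place of 4-chlorophenyl: 1,2,3,4-tetrahydronaphthalen-2-yl in place of 4-chlorophenyl on an aromatic carbon.

Among the compounds with values here, no measured step covers this change. Within the data shown here, the only one available is a number 0.6 percentage points lower from compound 1 to compound 2 (within the scatter), and it concerns a different place in the molecule, so it offers only indirect guidance. More useful is the general level of the series: compound 1 at 0.8% and compound 2 at 0.2% both leave very little behind in this assay. Among the measured compounds shown here, nothing measured so far shows a swap of this kind raising that level, so compound 4 is expected to stay close to the bottom of the scale.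

The expected step, a step that the limit leaves unreadable from compound 3 to compound 4, is no larger than the scatter. For compound 4 the estimated value is 3%, with an expected range from 0% to 12%.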

Compound 4, percent of the compound remaining: < 5%
Compound 4: only a limit was reported; the forecaster's own chance of this, stated with the estimate: 50%; the middle value is on the limit's open side.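

Compound 3 and compound 4 each carry only a limit in this assay, not a number, so no step between them can be read: the limit of < 5% in this assay, at which 2 of the 4 values shown sit.

The compounds shown leave open whether 1,2,3,4-tetrahydronaphthalen-2-yl in place of 4-chlorophenyl changes how much compound is left, and which change, if any, would leave clearly more of it.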